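The source may hold more compounds than are shown below. What is called first, only, known or untested is meant among the compounds shown, and "the series" means these compounds.

The series shares one core, carried by compound 3, `O=c1nc2occc2cn1COCCO`, which has a hydrogen where the other members bear a chain. Its read-out in a functional assay on HEL cells (Homo sapiens), read by microscopy (a higher number here means that more compound is tolerated, a lower number that less compound is tolerated), is a limit of the assay: compound 3 gives > 400000 nM, so only a bound is known for it, and it stands at the limit of > 400000 nM in this assay, at which 1 of the 3 values shown sits. Compound 1, `CCCCCCCCCCCc1cc2cn(COCCO)c(=O)nc2o1`, in this assay gives 80000 nM. Compound 2, `CCCCCCCCCc1cc2cn(COCCO)c(=O)nc2o1`, reaches only a limit of the assay in this assay, at >= 16000 nM, the bound described by the limit of >= 16000 nM in this assay, at which 1 of the 3 values shown sits. Within the data shown here, the one step between measured neighbours, a step that the limit leaves unreadable from compound 1 to compound 2, is therefore of unreadable size. Compound 4, `CCCCCc1cc2cn(COCCO)c(=O)nc2o1`, is reached from compound 3 by pentyl in place of hydrogen on an aromatic carbon. Among the measured compounds shown here, no measured step covers this change; the two limits and the value of compound 1 show only that a chain on this carbon can bring the minimum cytotoxic concentration into the readable range. Compound 4 is expected to give 200000 nM, in the range 50000 nM to 400000 nM, with a fair chance of another limit. This corresponds to an expected step of an at least 2.0-fold lower number from compound 3 to compound 4 (0.30 log units; that floor lies within the scatter).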

Compound 4, minimum cytotoxic concentration: > 400000 nM
Compound 4 gave a limit, no number; the forecaster's own chance of this, stated with the estimate: 60%; middle value at least 2.0-fold (0.30 log units) from the limit.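

In this assay compound 4, with pentyl on the aromatic carbon next to the ring oxygen, stays at a limit of the assay, the same limit as compound 3: the limit of > 400000 nM in this assay, at which 2 of the 4 values shown sit. A pentyl chain on this carbon therefore does not yet bring the minimum cytotoxic concentration into the readable range, so a chain here is not enough on its own. Hydrogen in place of hexyl on the chain gives an at least 5.0-fold higher number from compound 1 to compound 4 (0.69 log units; beyond the scatter), the first readable step in the series, and of the chains shown only the one in compound 1 gives a number.

From the compounds shown here alone, the steps joining compound 4 to compound 3 and to compound 2 cannot be read, so the chain length at which a number first appears remains open. Going by these compounds, whether a chain longer than that of compound 1, or a phenyl group on this carbon, would lower the tolerated concentration also remains open.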